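Adding a hydroxy group to compound 2

This account rests on a few compounds, and the source may have more. Where it says the series, first, only, none or still open, it means among the compounds named here.

Of the compounds shown here, two have so far been tested in a functional assay on K562 cells (Homo sapiens) for cytotoxicity, read by MTT assay, with a stated time of 5 days; on this read-out higher numbers stand for weaker inhibition and lower numbers for stronger inhibition. Compound 1 (`COc1ccc(Cn2nncc2-c2cc(OC)c(OC)c(OC)c2)cc1Br`) gives only a limit of the assay, > 10000 nM. Within the data shown here, compound 2 (`COc1ccc(-c2cnnn2Cc2cc(OC)c(OC)c(OC)c2)cc1`) gives 5560 nM, the only actual number available, so it cannot yet be ranked against a second measured figure.

Compound 3 (`COc1ccc(-c2cnnn2Cc2cc(OC)c(OC)c(OC)c2)cc1O`) differs from compound 2 in one place: hydroxy in place of hydrogen on an aromatic carbon. A hydroxy group takes the place of hydrogen on an aromatic carbon, ortho to a methoxy group, turning 4-methoxyphenyl into 3-hydroxy-4-methoxyphenyl. Among the measured compounds shown here, no measured pair isolates a single change, so this expectation rests on little. A moderate move towards stronger inhibition is expected, with an estimated 3.1-fold lower number from compound 2 to compound 3 (0.49 log units; beyond the scatter), although a change no larger than the scatter would not be surprising. For compound 3 the expected value is 1800 nM, with an estimated range from 250 nM to 9000 nM.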

Compound 3, half-maximal inhibitory concentration: 530 nM
For compound 3 the middle estimate is 3.4-fold (0.53 log units) above the measured one; measured number inside the range.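

Replacing hydrogen with hydroxy on an aromatic carbon, ortho to a methoxy group, proves to matter here: in this assay, going from 4-methoxyphenyl to 3-hydroxy-4-methoxyphenyl gives a 10-fold lower number from compound 2 to compound 3 (1.02 log units; beyond the scatter) and is a large change. Among these compounds, this is the first comparison that isolates one place, and it shows that this position responds strongly to the addition of a single oxygen atom. Nothing shown here accounts for the size of this step.

The compounds shown leave open whether the hydroxy group is specifically required, since an amine, a fluorine or a hydroxymethyl group at the same place would separate that group from other substituents. Going by these compounds, it also remains open whether the same change would carry over to the core of compound 1.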